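The compounds below may be only part of what the source reports. "The series", "measured", "known", "first", "only" and "open" are said of these compounds alone.

Measured so far in a functional assay for inhibition, with Homo sapiens as the target; on this read-out lower numbers stand for stronger inhibition and higher numbers for weaker inhibition:
Compound 1 `O=C(O)CCNC(=O)c1ccc2c(c1)C(=O)N(CCC1CCNCC1)C2` gives 27 nM.
Compound 2 `CCCCCS(=O)(=O)N[C@@H](CNC(=O)c1ccc2c(c1)C(=O)N(CCC1CCNCC1)C2)C(=O)O` gives 9 nM.
Compound 3 `CCCCNC(=O)N[C@@H](CNC(=O)c1ccc2c(c1)C(=O)N(CCC1CCNCC1)C2)C(=O)O` gives 16 nM.

Compound 3 holds the second highest of these three numbers, and it sits within the scatter of both neighbours: a 1.7-fold lower number from compound 1 to compound 3 (0.23 log units; within the scatter) and a 1.8-fold higher number from compound 2 to compound 3 (0.25 log units; within the scatter). The unmeasured compound 4 `O=C(NC[C@H](NS(=O)(=O)c1ccccc1C(=O)O)C(=O)O)c1ccc2c(c1)C(=O)N(CCC1CCNCC1)C2` differs from compound 3 in one place: (2-carboxyphenyl)sulfonyl in place of butylcarbamoyl on an amine nitrogen. Within the data shown here, two measured steps bear on this change. One is the exchange between a sulfonyl group and a carbamoyl group on the same amine nitrogen, a 1.8-fold higher number from compound 2 to compound 3 (0.25 log units; within the scatter). The other is the introduction of a sulfonyl-bearing substituent in place of hydrogen, a 3.0-fold lower number from compound 1 to compound 2 (0.48 log units; beyond the scatter), a modest step. Returning to a sulfonyl group is therefore expected to give a small step, a 1.6-fold lower number from compound 3 to compound 4 (0.20 log units; within the scatter), at the edge of the scatter. Compound 4 is estimated at 10 nM, in a range from 4 nM to 25 nM.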

Compound 4, half-maximal inhibitory concentration: 15 nM
Compound 4: middle estimate off by 1.5-fold (0.18 log units), on the low side; measured number inside the range.
By their numbers in this assay, from the lowest: compounds 2, 4, 3 and 1 (each within the scatter of the next, the first and the last beyond it).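

In this assay, the amine nitrogen takes (2-carboxyphenyl)sulfonyl in place of butylcarbamoyl with no real difference (a 1.1-fold lower number from compound 3 to compound 4 (0.03 log units; within the scatter)). On the sulfonyl sulfur, 2-carboxyphenyl in place of pentyl also stays within the scatter (a 1.7-fold higher number from compound 2 to compound 4 (0.22 log units; within the scatter)), so at this position a ring carrying a carboxylic acid reads the same as either plain chain. No measurement at hand explains this tolerance. Going by these compounds, it remains open whether a plain phenyl group without the carboxylic acid would read the same. On these data alone, an amine on that ring, or a longer chain on the sulfonyl sulfur, is equally open.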